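The source may hold more compounds than are shown below. What is called first, only, known or untested is meant among the compounds shown, and "the series" means these compounds.

Working notes on the series, read in an ADME assay on microsomes from liver (Homo sapiens) for metabolic stability, read by HPLC, using NADPH, with a stated time of 60 min, tested at 1 uM, in the presence of a further agent that is not named here; on this read-out higher numbers stand for a longer-lived compound and lower numbers for a shorter-lived compound. Compound 1 `Cc1cc(-n2cccn2)cc(C(=O)NNS(=O)(=O)c2ccccc2)c1F` gives 1.25 h. Compound 2 `O=C(NNS(=O)(=O)c1ccccc1F)c1cccc(-n2cccn2)c1` gives 2.35 h, within the scatter of compound 1, so the two stand level. Compound 3 `CCOc1cc(C)cc(C(=O)NNS(=O)(=O)c2ccccc2F)c1` gives 0.15 h, lower than compound 1 by a gap beyond the scatter. Compound 1 therefore sits with compound 2 in the upper part of this small set of three numbers.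

Compound 4 `C=CCOc1cc(C)c(F)c(C(=O)NNS(=O)(=O)c2ccccc2)c1` has not yet been measured. It keeps the core of compound 1 and changes one group: allyloxy in place of 1H-pyrazol-1-yl on an aromatic carbon, para to a fluoro group (allyloxy in place of 1H-pyrazol-1-yl on an aromatic carbon).

Among the compounds with values here, no measured pair isolates this change, so any expectation rests on indirect evidence. Within the data shown here, the two compounds with 1H-pyrazol-1-yl are compound 1 and compound 2, and the one compound with an ether group instead is compound 3, at 0.15 h. Compound 3 also differs from compound 1 elsewhere, so this comparison is loose, and three compounds establish no rule. A fall beyond the scatter is still the likelier outcome in this assay.

The expected step is a 4.2-fold lower number from compound 1 to compound 4 (0.62 log units; beyond the scatter). Compound 4 is estimated at 0.3 h, with an expected range of 0.1 h to 0.9 h.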

Compound 4, half-life: 0.4 h
Estimate against measurement, compound 4: 1.3-fold (0.12 log units) below; the measured number falls inside the stated range.
By their numbers in this assay, from the lowest: compound 3; then compound 4; then compounds 1 and 2 (each within the scatter of the next).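

In this assay the series now has its first pair that differs in one place, and allyloxy in place of 1H-pyrazol-1-yl on an aromatic carbon, para to a fluoro group, gives a 3.1-fold lower number from compound 1 to compound 4 (0.49 log units; beyond the scatter). Within the data shown here, with the rest of compound 1 held fixed, the half-life therefore responds to the group at this aromatic carbon, which the earlier compounds could not show, since each of them differs from compound 1 in more than one place. Nothing measured here bears on the reason for this step, so it stands as an observation only.

As far as these compounds go, this single step cannot separate the removal of the five-membered aromatic ring from the arrival of the ether oxygen or the double bond, so it remains open whether a saturated propoxy or a shorter methoxy group at this carbon would stand with compound 4 or with compound 1. From the compounds shown here alone, it also remains open how an amine or an imidazol-1-yl group would read at this carbon, and whether the same exchange gives a step of similar size on a different core.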